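A few compounds are considered here, and "the series" means these few. Any claim that something is new, unique, unknown or untested is made for them only; others in the source may bear on it.

Compound 1 `C#CC(=O)N(Cc1ccc(OC)c(O)c1)c1cc(OC)c(OC)c(OC)c1` gives 570 nM in a functional assay on KYSE-450 cells (Homo sapiens) for inhibition, read by MTT assay, with a stated time of 48 h (a higher number here means a weaker inhibitor, a lower number a stronger inhibitor), and compound 2 `COc1ccc(CN(C(=O)CO)c2cc(OC)c(OC)c(OC)c2)cc1O` gives 370 nM. Of these two numbers in this assay compound 2 holds the lower, but compound 1 lies within the scatter of it, so no ordering is claimed. Compound 3 `COc1ccc(CN(C(=O)C(C)C)c2cc(OC)c(OC)c(OC)c2)cc1O` carries isopropyl in place of hydroxymethyl on a carbonyl carbon. Among the compounds with values here, the only step measured so far on the carbonyl carbon, a 1.5-fold lower number from compound 1 to compound 2 (0.19 log units; within the scatter), stayed within the scatter. The present change again alters only the group on that carbonyl carbon, so no step beyond the scatter is expected in this assay. Compound 3 is therefore estimated at 500 nM, within 200 nM to 1500 nM, an expected step of a 1.4-fold higher number from compound 2 to compound 3 (0.13 log units; within the scatter).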

Compound 3, half-maximal inhibitory concentration: 390 nM
For compound 3 the middle estimate is 1.3-fold (0.11 log units) above the measured one; the range from low to high includes it.
By their numbers in this assay, from the lowest: compounds 2, 3 and 1 (each within the scatter of the next).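

In this assay, isopropyl in place of hydroxymethyl gives a 1.1-fold higher number from compound 2 to compound 3 (0.02 log units; within the scatter) and isopropyl in place of ethynyl gives a 1.5-fold lower number from compound 1 to compound 3 (0.16 log units; within the scatter) on the same carbonyl carbon. The steps at this position now include a group with no hydrogen-bond donor or acceptor, and none leaves the scatter, so compounds 1, 2 and 3 cannot be ordered here. Nothing available explains this result.

Still open, on these data alone, is whether a carboxylic acid, an amine or a longer chain on this carbonyl carbon would give a step beyond the scatter.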